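Ester variation on the enamide series: benzyl for tert-butyl

This account rests on a few compounds, and the source may have more. Where it says the series, first, only, none or still open, it means among the compounds named here.

Compound 1 `CC(C)(C)OC(=O)/C=C/NC(=O)[C@H](O)C(C)(C)CO` stands second highest of the three numbers in an ADME assay on WI-38 cells (Homo sapiens) for inhibition, read by CellTiter-Glo, with a stated time of 48 h, tested at 100 uM (on this read-out lower numbers stand for less inhibition and higher numbers for more inhibition at the one concentration tested (going by the name of the read-out)), with 0%. Compound 2 `CCOC(=O)/C=C/NC(=O)[C@@H](O)C(C)(C)CO` gives -6%, which lies within the scatter of compound 1, so no order between these two can be stated. Compound 3 `CC(C)(C)OC(=O)/C=C/NC(=O)[C@@H](O)C(C)(C)CO` gives 14%, the highest of the three. The two measured steps are a number 14 percentage points higher from compound 1 to compound 3 (beyond the scatter), a pair that differs only in configuration as drawn (the fact that compounds 1 and 3 differ only in the configuration as drawn), and a number 20 percentage points higher from compound 2 to compound 3 (beyond the scatter).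

Compound 4 `CC(C)(CO)[C@@H](O)C(=O)N/C=C/C(=O)OCc1ccccc1` has not been measured in this assay. It differs from compound 1 by benzyl in place of tert-butyl on an oxygen next to a carbonyl group. Within the data shown here, the only measured step that changes the group on that oxygen is a number 20 percentage points higher from compound 2 to compound 3 (beyond the scatter), a modest rise when tert-butyl replaces ethyl; it was observed at the other configuration, and no step at the configuration of compound 1 varies this group. Benzyl has not been tested anywhere in the set, so the direction of the step is open. Among the measured compounds shown here, since the one ester change moved the number only modestly, a small step is expected for compound 4, a number 5 percentage points higher from compound 1 to compound 4 (within the scatter). Compound 4 is estimated in this assay at 5%, with an expected range from -10% to 22%.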

Compound 4, a percentage reported as inhibition, at one concentration (the size of the read-out at that concentration, not a potency): 19%
Beside the measured number, compound 4's estimate is 14 percentage points below it; the range from low to high includes it.
By their numbers in this assay, from the lowest: compounds 2 and 1 (each within the scatter of the next); then compounds 3 and 4 (each within the scatter of the next).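

In this assay, among these compounds, benzyl in place of tert-butyl on an oxygen next to a carbonyl group gives a number 19 percentage points higher from compound 1 to compound 4 (beyond the scatter) as its step, the first change of this group at the configuration of compound 1. The group on this oxygen therefore moves the number at both drawn configurations, and not only at the other one, where tert-butyl replaced ethyl. This is also the first aromatic ring at this place, and it shows that a six-membered aromatic ring of carbon only is compatible with a number beyond the scatter of compound 1, though nothing shown here accounts for the rise.

The compounds shown leave open how benzyl behaves at the configuration of compound 3, and whether the step follows the aromatic ring itself or simply the larger group, a question that a cyclohexylmethyl ester would separate. Also open, from the compounds shown here alone, is how a longer chain such as n-butyl, or a carboxylic acid in place of the ester, would read in this assay.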